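A few compounds are considered here, and "the series" means these few. Any claim that something is new, unique, unknown or untested is made for them only; others in the source may bear on it.

Compound 2 `CC(C)C(Nc1nccs1)c1ccc(-c2ccc3cccc(F)c3c2)[nH]c1=O` is the stronger of the two measured compounds in an assay on CHO cells for displacement of a labelled ligand from prostaglandin E2 receptor EP3 subtype (Homo sapiens), read by radioligand binding (a higher number here means a weaker inhibitor, a lower number a stronger inhibitor), where compound 2 gives 9.4 nM. Its only measured neighbour is compound 1 `CC(C)C(c1ncco1)c1ccc(-c2ccc3cccc(F)c3c2)[nH]c1=O`, which in this assay gives 24 nM, so compound 2 stands lowest on the numbers shown, and the single step connecting them is a 2.6-fold lower number from compound 1 to compound 2 (0.41 log units; beyond the scatter).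

The next compound, compound 3 `CC(C)C(c1ncc[nH]1)c1ccc(-c2ccc3cccc(F)c3c2)[nH]c1=O`, differs from compound 2 by 1H-imidazol-2-yl in place of (1,3-thiazol-2-yl)amino on a saturated chain carbon bound to an aromatic carbon and a saturated chain carbon. Within the data shown here, only one measured step bears on this change, and only indirectly: the step from compound 1 to compound 2 swapped a directly bound five-membered ring for an amino-linked one, and compound 3 reverses the link while keeping a five-membered ring with two hetero atoms. Since that step was modest, the return to a directly bound ring is expected to give a modest move back toward the number of compound 1, an expected step of a 2.1-fold higher number from compound 2 to compound 3 (0.33 log units; beyond the scatter). Compound 3 is therefore estimated at 20 nM in this assay, with a plausible range from 7 nM to 60 nM.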

Compound 3, inhibition constant: 7.3 nM
Compound 3: the middle estimate sits 2.7-fold (0.44 log units) above what was measured; the measured number falls inside the stated range.
By their numbers in this assay, from the lowest: compounds 3 and 2 (each within the scatter of the next); then compound 1.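

In this assay, the result shows that this position on the saturated chain carbon does not depend on the amino link: the directly bound 1H-imidazol-2-yl and the (1,3-thiazol-2-yl)amino group cannot be told apart (a 1.3-fold lower number from compound 2 to compound 3 (0.11 log units; within the scatter)). It also shows that a direct bond to the ring does not by itself set the number, since the two directly bound rings do differ, with compound 1 as the weakest of the three (a 3.3-fold lower number from compound 1 to compound 3 (0.52 log units; beyond the scatter)). So the identity of the ring counts at this position even where the link stays the same, although no measurement at hand accounts for the gap between the 1,3-oxazol-2-yl and 1H-imidazol-2-yl groups.

The compounds shown leave open what an amino link would do to the 1,3-oxazol-2-yl ring, and whether the ring hydrogen of 1H-imidazol-2-yl matters, which a methyl group on that ring nitrogen would test. They also leave open whether a ring is needed here at all, as a simple amine or a carboxylic acid on the same carbon could show.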